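Weak cytotoxicity in a series sharing one lactone core

A few compounds are considered here, and "the series" means these few. Any claim that something is new, unique, unknown or untested is made for them only; others in the source may bear on it.

Compound 1 `COC(=O)CNC(=O)CCC(=O)Oc1ccc(C[C@H]2C(=O)OC[C@@H]2Cc2ccc(OC)c(OC)c2)cc1OC`: 179000 nM
Compound 2 `COc1ccc(C[C@H]2COC(=O)[C@@H]2Cc2ccc(OCC(=O)Nc3ccccc3)c(OC)c2)cc1OC`: >= 600000 nM
Compound 3 `CCN1CCN(C(=O)CCC(=O)Oc2ccc(C[C@H]3C(=O)OC[C@@H]3Cc3ccc(OC)c(OC)c3)cc2OC)CC1`: 190000 nM

In an ADME assay on HeLa cells (Homo sapiens) for cytotoxicity, read by MTT assay (on this read-out higher numbers stand for weaker inhibition and lower numbers for stronger inhibition), compound 1 gives 179000 nM. In this assay compound 3 gives 190000 nM, so a 1.1-fold higher number from compound 1 to compound 3 (0.03 log units; within the scatter). For compound 2 the assay reports only a limit, >= 600000 nM, and no number. Compound 2 therefore stands at the limit of >= 600000 nM in this assay, at which 1 of the 3 values shown sits, and the step of an at least 3.3-fold higher number from compound 1 to compound 2 (0.52 log units; beyond the scatter) can only be read as a lower bound.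

The compound not yet measured, compound 4 `COc1ccc(C[C@H]2COC(=O)[C@@H]2Cc2ccc(OCc3cn(-c4ccc(Cl)cc4)nn3)c(OC)c2)cc1OC`, differs from compound 2 by 1-(4-chlorophenyl)-1H-1,2,3-triazol-4-yl in place of phenylcarbamoyl on a saturated chain carbon bound to an oxygen on an aromatic ring. Neither measured step concerns this kind of exchange: one stays within the scatter, the other runs into the limit. With compound 2 itself known only as a limit, no step beyond the scatter is expected in this assay in either direction. Compound 4 is expected to give about 450000 nM, in the range 120000 nM to 1500000 nM. This estimate means an at least 1.3-fold lower number from compound 2 to compound 4 (0.12 log units; that floor lies within the scatter), and a further limit rather than a number is considered likely.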

Compound 4, half-maximal inhibitory concentration: 279000 nM
Compound 4: middle estimate off by 1.6-fold (0.21 log units), on the high side, within the range that was stated.
By their numbers in this assay, from the lowest: compounds 1, 3 and 4 (each within the scatter of the next). At a limit, above all of these: compound 2.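

Putting 1-(4-chlorophenyl)-1H-1,2,3-triazol-4-yl in place of phenylcarbamoyl on a saturated chain carbon bound to an oxygen on an aromatic ring gives, in this assay, an at least 2.1-fold lower number from compound 2 to compound 4 (0.33 log units; beyond the scatter). Of the steps shown, this is the only one that leads from a limit to a number. It shows that the read-out at this place responds to the group carried there, with compound 4 at 279000 nM. The full size of the step stays unknown, as compound 2 has a limit and no number: the limit of >= 600000 nM in this assay, at which 1 of the 4 values shown sits.

The compounds shown do not separate the triazole from the 4-chlorophenyl group, which enter together. They also do not tell how a plain phenyl on the triazole, or an amine or a carboxylic acid on the same chain carbon, would read in this assay.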